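Iodo to methoxy on the shared core

A few compounds are considered here, and "the series" means these few. Any claim that something is new, unique, unknown or untested is made for them only; others in the source may bear on it.

Within the data shown here, in a functional assay on SNB-75 cells (Homo sapiens) for inhibition (on this read-out higher numbers stand for weaker inhibition of growth and lower numbers for stronger inhibition of growth), compound 1 `NC(=O)c1cc(Cl)ccc1NC(=O)COc1ccccc1` gives 1810 nM and compound 2 `NC(=O)c1cc(I)ccc1NC(=O)COc1ccccc1` gives 215 nM, the lower of the two numbers so far. Among the measured compounds shown here, the only measured step is an 8.4-fold lower number from compound 1 to compound 2 (0.93 log units; beyond the scatter), with iodo in place of chloro on an aromatic carbon, and it lies beyond the scatter.

Compound 3 `COc1ccc(NC(=O)COc2ccccc2)c(C(N)=O)c1` carries methoxy in place of iodo on an aromatic carbon, para to a large group: methoxy in place of iodo on an aromatic carbon. For the measured compounds named here, no methoxy compound has been measured, so the halogen step bears on this change only indirectly. Going by the values given here, with compound 1 at 1810 nM as the sole measured compound without iodo, a step of similar size towards a higher number is expected in this assay. The expected step is a 7.0-fold higher number from compound 2 to compound 3 (0.84 log units; beyond the scatter). For compound 3 the estimated value is 1500 nM, with an expected range of 450 nM to 5000 nM.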

Compound 3, concentration for 50% growth inhibition: 245 nM
Compound 3: the middle estimate sits 6.1-fold (0.79 log units) above what was measured; measured number below the stated range.
By their numbers in this assay, from the lowest: compounds 2 and 3 (each within the scatter of the next); then compound 1.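

In this assay, replacing iodo with methoxy at this position, para to a large group, leaves the read-out within the scatter: a 1.1-fold higher number from compound 2 to compound 3 (0.06 log units; within the scatter). Methoxy also reproduces the gain over chloro, with a 7.4-fold lower number from compound 1 to compound 3 (0.87 log units; beyond the scatter), so the low number at this position is not confined to iodo and is not limited to halogens; among the three compounds, only the chloro compound 1 stands apart. Nothing available explains why these two quite different groups read alike or why chloro differs.

The compounds shown leave open whether bromo, an amine or a carboxylic acid at this position would fall with compound 2 and compound 3 or with compound 1. Also open, as far as these compounds go, is whether a longer chain such as ethoxy would keep the number of compound 3.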